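The source may hold more compounds than are shown below. What is called first, only, known or untested is meant among the compounds shown, and "the series" means these compounds.

Compounds measured in an assay on HeLa cells for inhibition of Kinesin-like protein KIF15 (Homo sapiens), read by microscopy, with stated times of 2 s and 20 s, tested at 750 nM; a lower number here means less inhibition, a higher number more inhibition at the concentration tested (going by the name of the read-out):

Compound 1, `O=C1Nc2ccc(C(=O)c3ccco3)cc2/C1=C/c1cc(F)c(O)c(Br)c1`: 38%
Compound 2, `O=C1Nc2ccc(C(=O)c3ccco3)cc2/C1=C/c1cc(Cl)c(O)c(Br)c1`: 62%
Compound 3, `COc1c(Br)cc(/C=C2\C(=O)Nc3ccc(C(=O)c4ccco4)cc32)cc1Br`: -12.6%

Compound 2 stands highest of the three numbers in this assay; the nearest is compound 1, lower by a step beyond the scatter, and the furthest is compound 3, lower by a much larger margin. Going by the values given here, the one step measured between neighbours is a number 24 percentage points higher from compound 1 to compound 2 (beyond the scatter), a modest gain that shows the halogen on the phenyl ring does move the read-out.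

Compound 4, `O=C1Nc2ccc(C(=O)c3ccco3)cc2/C1=C/c1ccc(Br)c(O)c1`, is not yet measured. From compound 2 it differs by a group of 8 heavy atoms (6 carbon, 1 oxygen, 1 bromine; one six-membered aromatic ring of carbon only) in place of a group of 9 heavy atoms (6 carbon, 1 oxygen, 1 chlorine, 1 bromine; one six-membered aromatic ring of carbon only), on a double-bonded chain carbon bound to a double-bonded ring carbon. The chlorine that compound 2 carries is gone, and the remaining bromine and hydroxyl sit in a 4-bromo-3-hydroxyphenyl arrangement. Among the compounds with values here, only the step from compound 1 to compound 2 bears on this change, and it points to a halogen-dependent read-out; removing the chlorine altogether is therefore expected to cost inhibition, by an estimated a number 32 percentage points lower from compound 2 to compound 4 (beyond the scatter). Compound 4 is expected to give about 30%, between 5% and 55%.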

Compound 4, a percentage reported as inhibition, at one concentration (the size of the read-out at that concentration, not a potency): -5.6%
Compound 4: middle estimate off by 35.6 percentage points, on the high side; the measured number lies below the stated range.
By their numbers in this assay, from the lowest: compounds 3 and 4 (each within the scatter of the next); then compound 1; then compound 2.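

In this assay, the change to 4-bromo-3-hydroxyphenyl gives a number 67.6 percentage points lower from compound 2 to compound 4 (beyond the scatter) and, from the fluoro partner, a number 43.6 percentage points lower from compound 1 to compound 4 (beyond the scatter) as well, so the group on this double-bonded chain carbon can matter far more than the exchange of one halogen for another suggested. The change is also more than the bare loss of a halogen: the bromine and the hydroxyl in compound 4 do not stand on the same ring places as in compound 1 and compound 2. No measurement shown here accounts for the size of this loss.

With the halogen count and the ring places changing together, the compounds shown cannot separate the two. From the compounds shown here alone, whether an amine or a carboxylic acid in place of the hydroxyl would retain any inhibition also stays open.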